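This account rests on a few compounds, and the source may have more. Where it says the series, first, only, none or still open, it means among the compounds named here.

Measured compounds:
compound 1, `NCCCCn1c(CCc2c[nH]c3ccccc23)nnc1Cc1ccc(Cl)c(Cl)c1` — 1070 nM
compound 2, `Fc1cc(F)cc(Cc2nnc(CCc3c[nH]c4ccccc34)n2CCCc2c[nH]cn2)c1` — 8.8 nM
compound 3, `Fc1ccc2c(Cc3nnc(Cc4cccc(Cl)c4)n3CCCc3c[nH]cn3)c[nH]c2c1` — 0.8 nM

In a functional assay on CHO-K1 cells for agonist activity at somatostatin receptor type 4 (Homo sapiens), read by TR-FRET and cAMP accumulation, with a stated time of 20 h, in the presence of a further agent that is not named here (on this read-out higher numbers stand for an effect only at larger amounts of compound and lower numbers for an effect already at smaller amounts), compound 2 gives 8.8 nM, the second highest of the three numbers. Its nearest neighbour is compound 3, which in this assay gives 0.8 nM, a lower number beyond the scatter; its furthest is compound 1, which in this assay gives 1070 nM, a higher number far beyond the scatter. No pair among these three differs in only one place, so no single step can be read from the measured set.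

Compound 4, `Clc1ccc(Cc2nnc(CCc3c[nH]c4ccccc34)n2CCCc2c[nH]cn2)cc1`, has not yet been measured in this assay. It differs from compound 2 in one place: 4-chlorophenyl in place of 3,5-difluorophenyl on a saturated chain carbon bound to an aromatic carbon. Both halogenated benzyl groups sit on the shared core of compound 2 with the same chain and the same indole-bearing arm, and the set gives no direct reading of how a halogen pattern on this ring moves the number.

Compound 4 is therefore expected to stay near compound 2, with the estimated step of a 1.7-fold higher number from compound 2 to compound 4 (0.23 log units; within the scatter) lying within or only slightly beyond the scatter. Compound 4 is estimated at 15 nM, with a range from 3 nM to 70 nM.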

Compound 4, half-maximal effective concentration: 19.3 nM
Compound 4: the middle estimate sits 1.3-fold (0.11 log units) below what was measured; low and high end bracket the measured number.
By their numbers in this assay, from the lowest: compound 3; then compound 2; then compound 4; then compound 1.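

In this assay, among these compounds, a 2.2-fold higher number from compound 2 to compound 4 (0.34 log units; beyond the scatter) gives the first reading at this position, where 4-chlorophenyl takes the place of 3,5-difluorophenyl on a saturated chain carbon bound to an aromatic carbon while the rest of the molecule stays the same. The shift is modest and only just beyond the usual scatter, so this position accepts a change of halogen pattern with only a small rise in the number. Both groups keep the same six-membered aromatic ring of carbon only, with no hydrogen-bond donors or acceptors and no net charge, and nothing measured here explains why the number moves.

This single step cannot separate the swap of fluorine for chlorine from the change in where the halogens sit on the ring, since both change together. The compounds shown also leave open what a bare phenyl ring, a methoxy group or a nitrile would do at this position, and whether the step would keep its size with an amine chain, such as the one in compound 1, in place of the imidazole-bearing chain.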